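A Shorter Side Chain on the Shared Core

The compounds below may be only part of what the source reports. "The series", "measured", "known", "first", "only" and "open" are said of these compounds alone.

Of the compounds shown here, two sharing one core have been tested in a functional assay on MCF7 cells (Homo sapiens) for antiproliferative activity, with a stated time of 48 h; a lower number here means a stronger inhibitor, a higher number a weaker inhibitor. Compound 1 `CCCCCc1cccc(NC(=O)NC(=O)CCl)c1` gives 8300 nM. Compound 2 `CCCCC(OC)c1cccc(NC(=O)NC(=O)CCl)c1` gives 6100 nM. Among the compounds with values here, the one measured step, a 1.4-fold lower number from compound 1 to compound 2 (0.13 log units; within the scatter), concerns methoxy in place of hydrogen on a saturated chain carbon bound to an aromatic carbon and a saturated chain carbon. Of these two numbers compound 2 holds the lower one, but its gap to compound 1 lies within the scatter, so the two cannot be ranked against each other.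

Compound 3 `CCCCC(OC)c1cccc(NC(=O)CCl)c1` has not yet been measured. It differs from compound 2 at a carbonyl carbon whose other neighbour is an amide-type nitrogen: chloromethyl in place of ((chloromethyl)carbonyl)amino on a carbonyl carbon. Cut one bond further out, ((chloromethyl)carbonyl)carbamoyl becomes (chloromethyl)carbonyl. Within the data shown here, no measured step touches this part of the molecule; the only step seen alters the methoxy-bearing chain and says nothing about the part that changes here. Lacking a guide, the expected step is a 1.1-fold higher number from compound 2 to compound 3 (0.06 log units; within the scatter), carrying wide uncertainty. Compound 3 is estimated at 7000 nM, expected to fall between 1500 nM and 30000 nM.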

Compound 3, half-maximal inhibitory concentration: 12000 nM
The estimate for compound 3 lay 1.7-fold (0.23 log units) below the measured number; measured number inside the range.
By their numbers in this assay, from the lowest: compounds 2, 1 and 3 (each within the scatter of the next).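

Within the data shown here, this step is the first to touch this part of the molecule. On the carbonyl carbon, the ((chloromethyl)carbonyl)amino group of 5 heavy atoms, which counts 1 hydrogen-bond donor and 1 hydrogen-bond acceptor, gives way to chloromethyl, a group of 2 heavy atoms with neither, and this assay records a 2.0-fold higher number from compound 2 to compound 3 (0.29 log units; within the scatter) for this change, so this sizeable cut in the structure does not separate the two compounds beyond ordinary repeat variation, and no ranking of them is possible. No measurement is available to explain how this part of the molecule relates to the antiproliferative read-out.

With only one replacement shown on this carbonyl carbon, it remains open whether other groups there, such as a methyl, an amine or a longer chain in place of chloromethyl, would give a step that clears the scatter. As far as these compounds go, it also remains open whether the chlorine itself matters, which a comparison of chloromethyl with plain methyl on an otherwise unchanged compound 3 could help to settle.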